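Moving the Methoxy Group: From Compound 1 to Compound 3

The source may report more compounds than this note shows. Statements on the series, on what has been measured and on what is new or still open speak of the compounds shown alone.

Within the data shown here, compound 1 `COc1ccccc1/C=C/C(=O)/C=C/c1ccc(OCc2cn(CCCCOc3cc(=O)oc4ccccc34)nn2)c(OC)c1` is one of two compounds measured in a functional assay on THP-1 cells (Homo sapiens) for inhibition, read by sulforhodamine B assay, with a stated time of 48 h, tested at 50 uM (on this read-out lower numbers stand for less inhibition of growth and higher numbers for more inhibition of growth at the one concentration tested), where compound 1 gives 40%. Compound 2 `COc1cccc(/C=C/C(=O)/C=C/c2ccc(OCc3cn(CCCCCOc4cc(=O)oc5ccccc45)nn3)c(OC)c2)c1` gives 37% in this assay, a value within the scatter of that of compound 1, so the two cannot be told apart on these numbers. Compound 3 `COc1ccc(/C=C/C(=O)/C=C/c2ccc(OCc3cn(CCCCOc4cc(=O)oc5ccccc45)nn3)c(OC)c2)cc1` has not yet been measured; it differs from compound 1 in one place: 4-methoxyphenyl in place of 2-methoxyphenyl on a double-bonded chain carbon bound to a double-bonded chain carbon. Among the measured compounds shown here, no measured pair isolates this change. The expected step of no change at the digits printed from compound 1 to compound 3 (within the scatter) is small, in no clear direction beyond the scatter. Compound 3 is therefore estimated at 40%, within a range from 25% to 55%.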

Compound 3, percent growth inhibition at one concentration: 45%
Estimate against measurement, compound 3: 5 percentage points below; measured number inside the range.
By their numbers in this assay, from the lowest: compounds 2, 1 and 3 (each within the scatter of the next).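

Among these compounds, putting 4-methoxyphenyl in place of 2-methoxyphenyl gives a number 5 percentage points higher from compound 1 to compound 3 (within the scatter) in this assay, the first measured pair to isolate this change. On this pair, the two groups cannot be told apart at this place on the chain, so the result shows no clear effect of the change. No evidence available here bears on this result.

Compound 2 differs from both compounds in more than one place, so it isolates no single change. On these data alone, whether a dimethylamino group or a carboxylic acid in place of the methoxy group would give a step beyond the scatter remains open.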